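The compounds below may be only part of what the source reports. "The series", "measured", "known", "first", "only" and "open" are said of these compounds alone.

Among the measured compounds shown here, compound 2 `Cc1nc(-c2ccc(C(F)(F)F)cc2)sc1CNc1ccc(CCC(N)=O)cc1` gives 12.9 nM in a functional assay on CHO cells for agonist activity at Free fatty acid receptor 1 (Homo sapiens) (on this read-out higher numbers stand for an effect only at larger amounts of compound and lower numbers for an effect already at smaller amounts), and is the only compound in the set with a number. Compound 1 `Cc1nc(-c2ccc(C(F)(F)F)cc2)sc1CNc1ccc(CC(=O)O)cc1` gives only a limit, < 10000 nM. The step that the limit leaves unreadable from compound 1 to compound 2 is therefore of unreadable size (the limit of < 10000 nM in this assay, at which 1 of the 2 values shown sits). Compound 3 `Cc1nc(-c2ccc(C(F)(F)F)cc2)sc1CNc1ccc([C@H]2C[C@@H]2C(=O)NO)cc1` carries 2-(hydroxycarbamoyl)cyclopropyl in place of 2-carbamoylethyl on an aromatic carbon. For the measured compounds named here, no measured step touches the 2-carbamoylethyl group, so nothing in the set sizes this change; the expectation rests on compound 2 alone. The step of a 3.1-fold higher number from compound 2 to compound 3 (0.49 log units; beyond the scatter) is expected. Compound 3 is estimated at 40 nM in this assay, between 8 nM and 300 nM.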

Compound 3, half-maximal effective concentration: 6.92 nM
Beside the measured number, compound 3's estimate is 5.8-fold (0.76 log units) above it, and the stated range ends above it.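

In this assay, 2-(hydroxycarbamoyl)cyclopropyl in place of 2-carbamoylethyl gives a 1.9-fold lower number from compound 2 to compound 3 (0.27 log units; within the scatter). This position, on an aromatic carbon para to a large group, therefore accepts a three-membered ring with two defined stereocentres and a hydroxycarbamoyl end without a change beyond the scatter. Compound 1 gives only a limit, so its step to compound 3 cannot be read: the limit of < 10000 nM in this assay, at which 1 of the 3 values shown sits.

Still open, going by these compounds, is how the ring and the hydroxycarbamoyl each contribute, which a 2-carbamoylcyclopropyl group or a 2-(hydroxycarbamoyl)ethyl chain would separate. On these data alone, the opposite stereoisomer of the cyclopropane and a 2-carboxyethyl group also remain open.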